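Ortho substitution on the benzyl ether and EP1 antagonism

The source may hold more compounds than are shown below. What is called first, only, known or untested is meant among the compounds shown, and "the series" means these compounds.

Of the compounds shown here, three sharing one core have been measured in a functional assay on CHO-K1 cells for antagonist activity at prostaglandin E2 receptor EP1 subtype (Homo sapiens), read by FLIPR; on this read-out higher numbers stand for weaker inhibition and lower numbers for stronger inhibition. Compound 1 `Cc1cc(C(=O)O)nn1Cc1cc(Br)ccc1OCc1ccc(Cl)cc1` gives 8.71 nM. Compound 2 `Cc1cc(C(=O)O)nn1Cc1cc(Br)ccc1OCc1ccccc1Cl` gives 28.8 nM, and compound 3 `COc1ccccc1COc1ccc(Br)cc1Cn1nc(C(=O)O)cc1C` gives 69.2 nM. Among these, compound 3 stands at the highest number, with compound 2 nearest and compound 1 furthest away. The measured steps were a 3.3-fold higher number from compound 1 to compound 2 (0.52 log units; beyond the scatter), a 2.4-fold higher number from compound 2 to compound 3 (0.38 log units; beyond the scatter) and a 7.9-fold higher number from compound 1 to compound 3 (0.90 log units; beyond the scatter).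

Compound 4 `Cc1cc(C(=O)O)nn1Cc1cc(Br)ccc1OCc1c(F)cccc1F` differs from compound 3 by 2,6-difluorophenyl in place of 2-methoxyphenyl on a saturated chain carbon bound to an oxygen on an aromatic ring. Among the compounds with values here, no measured step covers a fluorine substituent, so the expectation rests on the two ortho-substituted benzyl ethers already seen. The step of a 2.4-fold higher number from compound 2 to compound 3 (0.38 log units; beyond the scatter) shows that, with the substituent placed on the same ring position, replacing methoxy by a halogen lowered the number in this assay; compound 4 carries two fluorine atoms on that ring and no methoxy, so a move back toward the region of compound 2 is anticipated. The estimate for compound 4 is therefore a step of a 2.8-fold lower number from compound 3 to compound 4 (0.44 log units; beyond the scatter), a modest improvement, with compound 4 expected near 25 nM, within a range from 8 nM to 80 nM.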

Compound 4, inhibition constant: 105 nM
Compound 4: the middle estimate sits 4.2-fold (0.62 log units) below what was measured; measured number outside the range, above it.
By their numbers in this assay, from the lowest: compound 1; then compound 2; then compounds 3 and 4 (each within the scatter of the next).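

In this assay, 2,6-difluorophenyl in place of 2-methoxyphenyl on a saturated chain carbon bound to an oxygen on an aromatic ring gives a 1.5-fold higher number from compound 3 to compound 4 (0.18 log units; within the scatter), so this position does not separate these two groups, and removing the methoxy while adding two fluorines brings no return toward compound 2. Halogen on this ring is therefore not enough to hold the number down: exchanging 2-chlorophenyl for 2,6-difluorophenyl gives a 3.6-fold higher number from compound 2 to compound 4 (0.56 log units; beyond the scatter). Within the data shown here, the gap to the 4-chlorophenyl group also reaches a 12-fold higher number from compound 1 to compound 4 (1.08 log units; beyond the scatter), the only large step in the set, and compound 1 now stands apart from all three compounds with 2-chlorophenyl, 2-methoxyphenyl or 2,6-difluorophenyl, each of which gives a higher number.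

Nothing available here bears on why the 2,6-difluorophenyl group falls where it does. The compounds shown leave open whether a phenyl group without substituents, or one carrying a single fluorine or a trifluoromethyl, would stand nearer compound 1 or nearer compound 4, and so whether the number of fluorines or their placement matters at this position.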